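The source may hold more compounds than are shown below. What is called first, only, known or untested is meant among the compounds shown, and "the series" means these compounds.

Compound 1 `CCCCc1cc2c(=O)c(C(=O)OCC)c[nH]c2cc1OCCOc1ccccc1`: > 20000 nM
Compound 2 `CCCCc1cc2c(=O)c(C(C)=O)c[nH]c2cc1OCCOc1ccccc1`: "not determined" (no result reported)
Compound 3 `CCCCc1ccc2[nH]cc(C(=O)OC)c(=O)c2c1`: > 20000 nM

In an ADME assay on J774 cells (Mus musculus) for cytotoxicity (a higher number here means that more compound is needed for the effect, a lower number that less compound is needed), compound 3 gives > 20000 nM, which is a limit of the assay and not a number. Compound 1 gives > 20000 nM, which is also a limit. Compound 2 has no result, recorded as "not determined" (no result reported). Compound 4 `COC(=O)c1c[nH]c2ccccc2c1=O` has not yet been measured. Its change is hydrogen in place of butyl on an aromatic carbon. Among the compounds with values here, no measured step shows what this change does in this assay, so no step beyond the usual scatter is expected. The estimated step that the limit leaves unreadable from compound 3 to compound 4 is correspondingly small. For compound 4 the expected value is 25000 nM, with an estimated range of 15000 nM to 50000 nM.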

Compound 4, half-maximal effective concentration: > 20000 nM
Compound 4 ended at the assay's limit; the forecaster's own chance of this, stated with the estimate: 85%; the middle value is on the limit's open side.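

No step can be read from compound 3 to compound 4, because both values are limits of the assay and not numbers: the limit of > 20000 nM in this assay, at which 3 of the 4 values shown sit.
The compounds shown leave open whether hydrogen in place of butyl on an aromatic carbon changes the concentration needed for cytotoxicity at all.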